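Hydroxyphenyl placement across one shared three-aryl core

The compounds below may be only part of what the source reports. "The series", "measured", "known", "first", "only" and "open" are said of these compounds alone.

Measured so far:
Compound 1 `Oc1ccccc1-c1cc(-c2cccc(C(F)(F)F)c2)cc(-c2ccccc2O)n1`: in a functional assay on T47D cells (Homo sapiens) for inhibition (a higher number here means a weaker inhibitor, a lower number a stronger inhibitor), compound 1 gives > 50000 nM, which is a limit of the assay and not a number.
Compound 2 `Oc1cccc(-c2cc(-c3cccc(C(F)(F)F)c3)cc(-c3ccccc3O)n2)c1`: in this assay compound 2 gives 6340 nM.
Compound 3 `Oc1cccc(-c2cc(-c3ccc(OC(F)(F)F)cc3)cc(-c3ccccc3O)n2)c1`: in this assay compound 3 gives 7710 nM.

Within the data shown here, the one measured step is 3-hydroxyphenyl in place of 2-hydroxyphenyl on an aromatic carbon, which gave an at least 7.8-fold lower number from compound 1 to compound 2 (0.89 log units; beyond the scatter); the size rests on (the limit of > 50000 nM in this assay, at which 1 of the 3 values shown sits). Compound 2 and compound 3 sit within the scatter of each other. How the core of compound 3 differs from that of compound 1 is not broken down here.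

Compound 4 `Oc1cccc(-c2cc(-c3ccc(OC(F)(F)F)cc3)cc(-c3cccc(O)c3)n2)c1` is not yet measured. It stands to compound 3 as compound 2 stands to compound 1: 3-hydroxyphenyl in place of 2-hydroxyphenyl on an aromatic carbon. The surroundings are not identical: in the earlier pair the place was meta to a 2-hydroxyphenyl group and meta to a 3-(trifluoromethyl)phenyl group, here it is meta to a 3-hydroxyphenyl group and meta to a large group, so this is the same kind of change rather than the same one. A step of roughly the earlier size is expected, a 5.1-fold lower number from compound 3 to compound 4 (0.71 log units; beyond the scatter), resting on an at least 7.8-fold lower number from compound 1 to compound 2 (0.89 log units; beyond the scatter) of compound 1 to compound 2. Compound 4 is therefore estimated at 1500 nM in this assay, expected between 400 nM and 6000 nM.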

Compound 4, half-maximal inhibitory concentration: 9820 nM
Estimate against measurement, compound 4: 6.5-fold (0.82 log units) below, outside the stated range (above it).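

In this assay the replacement of 2-hydroxyphenyl by 3-hydroxyphenyl does not carry over from one core to the other with the same effect: the same change on two cores in this assay, an at least 7.8-fold lower number (0.89 log units; beyond the scatter) from compound 1 to compound 2 and a 1.3-fold higher number (0.11 log units; within the scatter) from compound 3 to compound 4, at least 10-fold (1.00 log units) apart, beyond the scatter of two such steps On the second core the change gives a 1.3-fold higher number from compound 3 to compound 4 (0.11 log units; within the scatter), so the gain seen on the first core does not reappear there. Two pairs set no rule for the series, the cores differ both in the remaining hydroxyphenyl group and in the large group, the data do not say which of these differences matters, and the size of the earlier step is only a bound: the limit of > 50000 nM in this assay, at which 1 of the 4 values shown sits.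

Open, on these data alone, is whether the core of compound 3 behaves the same way once its trifluoromethoxy-bearing group gives way to the 3-(trifluoromethyl)phenyl group, a comparison that would separate the two core differences. Also open, as far as these compounds go, is what happens on either core when a hydroxyl on these rings is replaced by an amine or a carboxylic acid.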